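Trimming the Terminal Amine of Compound 1

A few compounds are considered here, and "the series" means these few. Any claim that something is new, unique, unknown or untested is made for them only; others in the source may bear on it.

Compound 1 `COc1cc(OC)c(Cl)c(-c2ccc3c(NC(=O)c4ccc(N5CCN(C)CC5)cc4)n[nH]c3n2)c1Cl` carries a 4-methylpiperazin-1-yl group on the amide-bearing aromatic ring. In a functional assay on NCI-H1581 cells (Homo sapiens) for antiproliferative activity, read by CCK-8 assay, with a stated time of 72 h (on this read-out lower numbers stand for stronger inhibition and higher numbers for weaker inhibition), compound 1 gives 1.7 nM, the lowest of the two numbers at hand. Among the compounds with values here, compound 2 `COc1cc(OC)c(Cl)c(-c2ccc3c(NC(=O)c4cnc(N5CCN(C)CC5)cn4)n[nH]c3n2)c1Cl` differs from it in more than one place; in this assay compound 2 gives 60.6 nM, a higher number by a margin beyond the usual scatter, and since no single-point step connects the two, only their two values can be compared. Compound 3 `COc1cc(OC)c(Cl)c(-c2ccc3c(NC(=O)c4ccc(N(C)C)cc4)n[nH]c3n2)c1Cl` has not yet been measured. Its change from compound 1 is dimethylamino in place of 4-methylpiperazin-1-yl on an aromatic carbon. No measured pair among these compounds shows a change of this kind, so the expected step of a 2.4-fold higher number from compound 1 to compound 3 (0.37 log units; beyond the scatter) is a small move toward a higher number, possibly none beyond the scatter. Compound 3 is expected to give about 4 nM in this assay, within a range of 1.2 nM to 15 nM.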

Compound 3, half-maximal inhibitory concentration: 294 nM
Beside the measured number, compound 3's estimate is 74-fold (1.87 log units) below it; measured number outside the range, above it.
By their numbers in this assay, from the lowest: compound 1; then compound 2; then compound 3.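

In this assay, within the data shown here, the exchange of 4-methylpiperazin-1-yl for dimethylamino on this aromatic carbon, para to a large group, gives a 170-fold higher number from compound 1 to compound 3 (2.24 log units; beyond the scatter) and is the first single-place change available. The step is large and beyond the scatter, so at this position an amine nitrogen on the aromatic carbon is not enough to keep the low number of compound 1, and the ring and remaining atoms that leave with the 4-methylpiperazin-1-yl group count for much in this read-out. Nothing in the data at hand accounts for the size of this step.

As far as these compounds go, what remains open is which part of the departing group matters: a piperidine or morpholine ring on this carbon, or a dimethylamino group carried on a longer chain, could separate the ring from the second nitrogen. From the compounds shown here alone, it also remains open whether the same exchange would have a similar effect in compound 2.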